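Hydroxy on the Pendant Phenyl of an Anilino Pyrimidine

The source may hold more compounds than are shown below. What is called first, only, known or untested is meant among the compounds shown, and "the series" means these compounds.

Of the compounds shown here, two have been measured in a functional assay on the whole organism (strain albino) for inhibition, with Rattus norvegicus as the target, read by paw edema, with stated times of 1 h and 2 h, at a dose of 100 mg/kg by the oral route; a higher number here means more inhibition at the dose given (going by the name of the read-out), a lower number less inhibition. Compound 1, `N#Cc1c(Cl)nc(SCC(=O)Nn2c(COc3ccc(Cl)cc3Cl)nc3ccccc3c2=O)nc1-c1ccc(O)cc1`, gives 73.7% in this assay. Compound 2, `N#Cc1c(Nc2ccccc2)nc(SCC(=O)Nn2c(COc3ccc(Cl)cc3Cl)nc3ccccc3c2=O)nc1-c1ccccc1`, gives 78.1% in this assay, the higher of the two numbers, though its gap to compound 1 lies within the scatter, so the two cannot be ranked. Compound 3, `N#Cc1c(Nc2ccccc2)nc(SCC(=O)Nn2c(COc3ccc(Cl)cc3Cl)nc3ccccc3c2=O)nc1-c1ccc(O)cc1`, has not yet been measured. It differs from compound 2 in one place: hydroxy in place of hydrogen on an aromatic carbon. The hydroxy enters on an aromatic carbon of a six-membered aromatic ring of carbon only, para to a large group. Within the data shown here, no step between measured compounds exists, so the expected size of this change rests only on the two values in hand. Compound 1 already carries the 4-hydroxyphenyl and sits within the scatter of compound 2, so no step beyond the scatter is expected; the step from compound 2 to compound 3 is estimated at a number 3.1 percentage points lower from compound 2 to compound 3 (within the scatter). Compound 3 is expected to give 75%, within 64% to 86%, in this assay.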

Compound 3, a percentage reported as inhibition, in the whole organism at one dose (the size of the read-out at that dose, not a potency): 91.2%
Estimate against measurement, compound 3: 16.2 percentage points below, outside the stated range (above it).
By their numbers in this assay, from the lowest: compounds 1 and 2 (each within the scatter of the next); then compound 3.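

In this assay, the change from phenyl to 4-hydroxyphenyl, with the anilino group in place, gives a number 13.1 percentage points higher from compound 2 to compound 3 (beyond the scatter). Among these compounds, this is the first reading of that change on its own, since compound 1 and compound 2 differ in more than one place. With the 4-hydroxyphenyl held fixed, anilino in place of chloro gives a number 17.5 percentage points higher from compound 1 to compound 3 (beyond the scatter), so compound 3 stands clear of both neighbours and each of its two groups counts in this setting.

Nothing measured here gives a reason for either step. Still open, as far as these compounds go, is whether a methoxy, an amine or a carboxylic acid on that ring would match the hydroxy, and whether the hydroxy step would hold with chloro in place of anilino.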